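This account rests on a few compounds, and the source may have more. Where it says the series, first, only, none or still open, it means among the compounds named here.

Compound 1 `CC(C)Cc1ccc2c(NCCCNCc3ccco3)ccnc2c1` is the reference of the series; in a physicochemical assay for acid dissociation, compound 1 gives 9.47. Compound 2 `c1ccc(Oc2ccc3c(NCCCNCc4ccco4)ccnc3c2)cc1` carries phenoxy in place of isobutyl on an aromatic carbon and in this assay compound 2 gives 9.28, a step of a number 0.19 log units lower from compound 1 to compound 2 (within the scatter). Compound 3 `COc1ccc(F)cc1CNCCCNc1ccnc2cc(CC(C)C)ccc12` differs from compound 1 by 5-fluoro-2-methoxyphenyl in place of furan-2-yl on a saturated chain carbon bound to an amine nitrogen; in this assay compound 3 gives 9.47, a step of no change at the digits printed from compound 1 to compound 3 (within the scatter). Compound 4 `COc1ccc(F)cc1CNCCCNc1ccnc2cc(Oc3ccccc3)ccc12` is not yet measured; it differs from compound 3 by phenoxy in place of isobutyl on an aromatic carbon, the same change that separates compound 1 from compound 2, made twice among these compounds. For compound 4 the expected step is a number 0.19 log units lower from compound 3 to compound 4 (within the scatter), because the same change gave a number 0.19 log units lower from compound 1 to compound 2 (within the scatter) on the core of compound 1. Compound 4 is therefore expected to give about 9.28 in this assay, likely between 9.05 and 9.5.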

Compound 4, acid dissociation constant: 9.28
Beside the measured number, compound 4's estimate shows no gap at the digits printed; the measured number falls inside the stated range.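

In this assay, replacing isobutyl with phenoxy gives a number 0.19 log units lower from compound 3 to compound 4 (within the scatter) and, on the core of compound 1, a number 0.19 log units lower from compound 1 to compound 2 (within the scatter), so the two steps read alike on both cores shown; with phenoxy present, replacing furan-2-yl with 5-fluoro-2-methoxyphenyl gives no change at the digits printed from compound 2 to compound 4 (within the scatter) as well. Since these steps lie within the scatter, the agreement does not show a real shift carried from one core to another, and two cores support no general rule for the series. Nothing available explains these numbers.

Still open, on these data alone, is how this assay reads when a carboxylic acid or a primary amine stands in place of isobutyl on the shared core. As far as these compounds go, a longer chain between the two amine nitrogens is equally open.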